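Swapping a pyridyl ether ahead of a rat exposure test

This account rests on a few compounds, and the source may have more. Where it says the series, first, only, none or still open, it means among the compounds named here.

Compound 2 `Cc1cnc(Oc2ccc3nc(COc4cccc(C(=O)O)c4)n(C)c3c2)c(F)c1` and compound 1 `Cn1c(COc2cccc(C(=O)O)c2)nc2cnc(Oc3ccc4c(c3)CCC4)cc21` were each dosed in an ADME assay on the whole organism (strain Zucker) for pharmacokinetics, with Rattus norvegicus as the target, with a stated time of 14 days, at a dose of 3 mg/kg by the oral route; a higher number here means more compound in the circulation at the dose given, a lower number less compound in the circulation. In this assay compound 2 gives 1030 nM, and compound 1 gives 987 nM; the two numbers lie within the scatter of each other, so neither stands apart. Compound 3 `Cc1cc(Cl)cnc1Oc1ccc2nc(COc3cccc(C(=O)O)c3)n(C)c2c1` awaits measurement. It differs from compound 2 by 5-chloro-3-methylpyridin-2-yl in place of 3-fluoro-5-methylpyridin-2-yl on an oxygen on an aromatic ring. Among the compounds with values here, no comparable step exists among the measured pair, so no shift beyond the scatter is expected, and the estimated step is a 1.1-fold lower number from compound 2 to compound 3 (0.06 log units; within the scatter). Compound 3 is therefore expected to give 900 nM, within a range of 400 nM to 2200 nM.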

Compound 3, maximal plasma concentration: 283 nM
Compound 3: the middle estimate sits 3.2-fold (0.50 log units) above what was measured; measured number outside the range, below it.
By their numbers in this assay, from the lowest: compound 3; then compounds 1 and 2 (each within the scatter of the next).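

At this place, on an oxygen on an aromatic ring, the choice of pyridine substituents matters: in this assay, 5-chloro-3-methylpyridin-2-yl in place of 3-fluoro-5-methylpyridin-2-yl gives a 3.6-fold lower number from compound 2 to compound 3 (0.56 log units; beyond the scatter). The two groups have the same counts of heavy atoms, donors and acceptors, so those counts do not track the shift. Nothing available explains the drop. The single step changes the halogen and the arrangement of the substituents together, so the compounds shown cannot separate the two. As far as these compounds go, how a methoxy group or an amine on this pyridine would read also remains open.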